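The source may report more compounds than this note shows. Statements on the series, on what has been measured and on what is new or still open speak of the compounds shown alone.

Compound 1 `Cn1ccc2c(Oc3ccc(NC(=O)c4cc5cccnc5n(-c5ccc(F)cc5)c4=O)cc3F)ccnc21`: 250 nM
Compound 2 `Cn1ccc2c(Oc3ccc(NC(=O)c4cc5cccnc5n(-c5ccc(Cl)cc5)c4=O)cc3F)ccnc21`: "not determined" (no result reported)

In a functional assay on NCI-H460 cells (Homo sapiens) for antiproliferative activity, read by MTT assay, with a stated time of 72 h (on this read-out lower numbers stand for stronger inhibition and higher numbers for weaker inhibition), compound 1 gives 250 nM. Compound 2 gives "not determined" (no result reported) in this assay, so it cannot be placed against compound 1. Compound 3 `Cn1ccc2c(Oc3ccc(NC(=O)c4cc5cccnc5n(-c5ccc(Br)cc5F)c4=O)cc3F)ccnc21` differs from compound 2 by 4-bromo-2-fluorophenyl in place of 4-chlorophenyl on an aromatic nitrogen. Among the compounds with values here, with no measured step in this assay to go by, no change beyond the scatter is expected from compound 2 to compound 3, and the only anchor is compound 1. Compound 3 is therefore estimated at 300 nM, within 100 nM to 900 nM.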

Compound 3, half-maximal inhibitory concentration: 3150 nM
Compound 3: the middle estimate sits 11-fold (1.02 log units) below what was measured; the measured number lies above the stated range.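

In this assay the group on the aromatic nitrogen now has its first readable step: 4-bromo-2-fluorophenyl in place of 4-fluorophenyl gives a 13-fold higher number from compound 1 to compound 3 (1.10 log units; beyond the scatter) and thus a clear loss of inhibition, so this position does not tolerate every halogenated phenyl equally. The step from compound 2 cannot be read. No measurement shown accounts for this loss.

The compounds shown leave open whether the bromine or the added fluorine of 4-bromo-2-fluorophenyl carries the loss. As far as these compounds go, how unsubstituted phenyl or a phenyl bearing an amine would read at this position also remains open.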